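The source may report more compounds than this note shows. Statements on the series, on what has been measured and on what is new or still open speak of the compounds shown alone.

Compound 1 `Nc1cc(N)c2nc(-c3ccccc3)c(Oc3ccc(Cl)c(Cl)c3)nc2c1`: < 100000 nM
Compound 2 `COc1cc(CNc2nc3cc(N)cc(N)c3nc2-c2ccccc2)cc(OC)c1OC`: < 50200 nM
Compound 3 `CCOC(=O)[C@H](CCC(=O)O)NC(=O)c1ccc(Oc2nc3cc(N)cc(N)c3nc2-c2ccccc2)cc1`: < 50200 nM

In a functional assay on PC-3 cells (Homo sapiens) for inhibition, read by sulforhodamine B assay, with a stated time of 48 h (a lower number here means that less compound is tolerated, a higher number that more compound is tolerated), compound 1 gives < 100000 nM, which is a limit of the assay rather than a number, so compound 1 stands at the limit of < 100000 nM in this assay, at which 1 of the 3 values shown sits. Compound 2 gives < 50200 nM, again only a limit. Compound 3 likewise gives < 50200 nM, a limit as well, so that compounds 2 and 3 share (the limit of < 50200 nM in this assay, at which 2 of the 3 values shown sit). Going by the values given here, no step between two measured compounds that differ in one place is available, and none of the three values is a number, so nothing can be said about the order of compounds 1, 2 and 3.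

Compound 4 `Nc1cc(N)c2nc(-c3ccccc3)c(Sc3ccc(Cl)c(Cl)c3)nc2c1` differs from compound 1 in one place: (3,4-dichlorophenyl)sulfanyl in place of 3,4-dichlorophenoxy on an aromatic carbon. With only limits to lean on, the expected step from compound 1 to compound 4 in this assay is none beyond the usual scatter, and the estimate a number no lower from compound 1 to compound 4 (the limit leaves the size open) reflects that. Compound 4 is accordingly expected to come out near 100000 nM, somewhere between 30000 nM and 300000 nM, most likely again reported only as a limit.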

Compound 4, concentration lethal to 50% of the cells: < 100000 nM
Compound 4 gave a limit, no number (the forecaster's own chance of this, stated with the estimate: 70%); the middle value sits exactly at the limit.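

In this assay compound 4 gives < 100000 nM, a limit and not a number. Going by these compounds alone, compound 1 gives < 100000 nM, again a limit, so no step between compound 1 and compound 4 can be read. As far as these compounds go, whether (3,4-dichlorophenyl)sulfanyl and 3,4-dichlorophenoxy differ at all on the shared core stays open.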